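Adding a methoxy group beside a nitro-bearing ring

A few compounds are considered here, and "the series" means these few. Any claim that something is new, unique, unknown or untested is made for them only; others in the source may bear on it.

Compound 2 `COc1ccc2nc(-c3ccc(N/C=C\C(=O)c4ccc(OC)c([N+](=O)[O-])c4)c(C)c3)sc2c1` gives 23600 nM in a functional assay on MIA PaCa-2 cells (Homo sapiens) for antiproliferative activity, read by sulforhodamine B assay, with a stated time of 48 h (a higher number here means a weaker inhibitor, a lower number a stronger inhibitor), the higher of the two numbers measured; its nearest neighbour, compound 1 `COc1ccc2nc(-c3ccc(N/C=C\C(=O)c4ccc(OC)c(O)c4)c(C)c3)sc2c1`, gives 17000 nM in this assay, and the step of a 1.4-fold higher number from compound 1 to compound 2 (0.14 log units; within the scatter) lies within the scatter. Compound 3 `COc1ccc2nc(-c3ccc(N/C=C\C(=O)c4cc(OC)c(OC)c([N+](=O)[O-])c4)c(C)c3)sc2c1` differs from compound 2 by methoxy in place of hydrogen on an aromatic carbon. Among the compounds with values here, no measured step involves adding a methoxy group, so nothing measured bears directly on this change. Compound 3 is therefore expected to show roughly the same number, an estimate of 20000 nM with a range of 7000 nM to 60000 nM in this assay. The expected step is a 1.2-fold lower number from compound 2 to compound 3 (0.07 log units; within the scatter).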

Compound 3, half-maximal inhibitory concentration: 12000 nM
Compound 3: the middle estimate sits 1.7-fold (0.22 log units) above what was measured; the range from low to high includes it.
By their numbers in this assay, from the lowest: compounds 3, 1 and 2 (each within the scatter of the next).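

In this assay, placing a methoxy group on this ring carbon, ortho to a methoxy group and meta to a nitro group, gives a 2.0-fold lower number from compound 2 to compound 3 (0.29 log units; within the scatter). Within the data shown here, compounds 1 and 2 both carry hydrogen at this carbon, so this step is the only reading here of a group placed there, and it shows that the added methoxy group leaves the number within the scatter. Nothing available explains this result. Still open, going by these compounds, is how an amine or a longer chain, such as ethoxy, would read at this carbon. Also open, on these data alone, is whether a methoxy group here would give a similar step with hydroxy in place of the nitro group.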